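This account rests on a few compounds, and the source may have more. Where it says the series, first, only, none or still open, it means among the compounds named here.

Working notes on the series in a functional assay on Hep 3B2 cells (Homo sapiens) for inhibition, read by MTT assay, with a stated time of 72 h; on this read-out higher numbers stand for weaker inhibition and lower numbers for stronger inhibition: compound 1 `CCc1nc2c(C)cc(-c3ccc(CN4CCC(O)CC4)cc3)cn2c1NC(=O)OCc1cc(Cl)cc(Cl)c1` stands as "nd" (no result reported) and compound 2 `CCc1nc2c(C)cc(-c3ccc(CN4CCC[C@H]4CO)cc3)cn2c1NC(=O)OCc1cc(Cl)cc(Cl)c1` stands as "nd" (no result reported), so they offer no comparison. Among the compounds with values here, compound 3 `CCc1nc2c(C)cc(-c3ccc(CN4CCN(C)CC4)cc3)cn2c1NC(=O)OCc1cc(Cl)cc(Cl)c1` gives 4900 nM, the only number available, and it cannot yet be ranked against anything. Compound 4 `CCc1nc2c(C)cc(-c3ccc(CN4CCC(C)CC4)cc3)cn2c1NC(=O)OCc1cc(Cl)cc(Cl)c1` remains to be measured. It carries 4-methylpiperidin-1-yl in place of 4-methylpiperazin-1-yl on a saturated chain carbon bound to an aromatic carbon. No measured pair in the series gauges a change of this kind in this assay, so only a small shift toward stronger inhibition is expected, possibly none beyond the scatter. The estimated move is a 1.4-fold lower number from compound 3 to compound 4 (0.15 log units; within the scatter). Compound 4 is expected at 3500 nM, with an estimated range of 1500 nM to 8000 nM.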

Compound 4, half-maximal inhibitory concentration: 4850 nM
For compound 4 the middle estimate is 1.4-fold (0.14 log units) below the measured one; measured number inside the range.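

Within the data shown here, with 4-methylpiperidin-1-yl in place of 4-methylpiperazin-1-yl on a saturated chain carbon bound to an aromatic carbon, this assay gives a 1.0-fold lower number from compound 3 to compound 4 (0.00 log units; within the scatter), the first comparison. This one exchange therefore does not separate the two groups on this read-out. No available measurement explains this result.

Steps involving compound 1 and compound 2 cannot be read, which leaves their hydroxyl-bearing amines unplaced. Also open, as far as these compounds go, is whether morpholin-4-yl, a primary amine or a carboxylic acid at this place would read differently.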